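Swapping dimethylamino for methoxy on the shared core

This account rests on a few compounds, and the source may have more. Where it says the series, first, only, none or still open, it means among the compounds named here.

Measured so far:
compound 1, `COc1ncnc2c1c(-c1cccs1)cn2[C@@H]1O[C@H](CO)[C@@H](O)[C@H]1O`, 80 nM
compound 2, `CN(C)c1ncnc2c1c(-c1cc3ccccc3o1)cn2[C@@H]1O[C@H](CO)[C@@H](O)[C@H]1O`, > 20000 nM

In a functional assay on HCT-116 cells (Homo sapiens), read by MTT assay, with a stated time of 72 h (a lower number here means a stronger inhibitor, a higher number a weaker inhibitor), compound 1 gives 80 nM. Compound 2 gives only a limit in this assay, > 20000 nM, so its true value is not known as a number; this is shown by the limit of > 20000 nM in this assay, at which 1 of the 2 values shown sits. Compound 1 and compound 2 differ from each other in two places, so nothing can be said about which of the two differences accounts for the gap between them.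

Compound 3, `COc1ncnc2c1c(-c1cc3ccccc3o1)cn2[C@@H]1O[C@H](CO)[C@@H](O)[C@H]1O`, has not yet been measured in this assay. It carries the change (methoxy in place of dimethylamino on an aromatic carbon). Compound 3 thus shares the methoxy of compound 1 and the rest of the structure of compound 2. Among the compounds with values here, since no step between measured compounds is available, the expectation rests only on these two points. Compound 3 is expected to be a stronger inhibitor than the limit of compound 2 suggests, with an expected step of an at least 6.6-fold lower number from compound 2 to compound 3 (0.82 log units; beyond the scatter). The estimate for compound 3 is 3000 nM, within a range from 200 nM to 20000 nM.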

Compound 3, half-maximal inhibitory concentration: 13800 nM
The estimate for compound 3 lay 4.6-fold (0.66 log units) below the measured number; the measured number falls inside the stated range.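

In this assay, the swap of dimethylamino for methoxy on an aromatic carbon of the shared core can now be read on its own, as an at least 1.4-fold lower number from compound 2 to compound 3 (0.16 log units; that floor lies within the scatter), so this pair alone does not show that the swap matters, nor that it does not. Compound 2 gives only a limit, so that step is a floor and its true size stays unknown: the limit of > 20000 nM in this assay, at which 1 of the 3 values shown sits.

The other place now shows a clear effect. With methoxy held fixed, 1-benzofuran-2-yl in place of thiophen-2-yl on an aromatic carbon gives a 170-fold higher number from compound 1 to compound 3 (2.24 log units; beyond the scatter), which means that methoxy on its own does not secure the strength seen with the thiophen-2-yl group.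

The compounds shown leave open how dimethylamino behaves alongside thiophen-2-yl, and so whether the swap of dimethylamino for methoxy counts for more with that smaller ring than with 1-benzofuran-2-yl. Also open, from the compounds shown here alone, is how a primary amine or a longer chain such as ethoxy would compare with methoxy at the same place on the shared core.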